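The source may report more compounds than this note shows. Statements on the series, on what has been measured and on what is new or still open speak of the compounds shown alone.

Compound 1 `CC1=CC[C@H]2[C@@H]([C@@H]1CC[C@H]1[C@]3(C)CC[C@H](O)C(C)(C)O[C@H]3CC[C@@]1(C)O)C(C)(C)CC[C@]2(C)O` and compound 2 `CC1(C)O[C@H]2CC[C@@](C)(O)[C@@H](CC[C@@H]3C(CO)=CC[C@H]4[C@H](CC[C@]4(C)O)C3(C)C)[C@]2(C)CCC1=O` share the same core with small differences at its edges. In a functional assay on MDA-MB-231 cells (Homo sapiens) for antiproliferative activity, read by MTT assay, with a stated time of 72 h (a lower number here means a stronger inhibitor, a higher number a weaker inhibitor), compound 1 gives > 50000 nM, which is a limit of the measurement rather than a number. Compound 2 likewise gives only a limit in this assay, > 50000 nM. Within the data shown here, compound 2 therefore stands where the numbers run out: the limit of > 50000 nM in this assay, at which 2 of the 2 values shown sit, so no measured step separates the two compounds. Compound 3 `CC1(C)O[C@H]2CC[C@@](C)(O)[C@@H](CC[C@@H]3C(C=O)=CC[C@H]4[C@H](CC[C@]4(C)O)C3(C)C)[C@]2(C)CCC1=O` follows from compound 2 by a single change, (formyl in place of hydroxymethyl on a double-bonded ring carbon). Among the measured compounds shown here, no measured pair here shows what such a change does, so the size of the step in this assay cannot be read from these data; a move beyond the scatter in either direction would be a surprise, though a small gain cannot be excluded. For compound 3 the estimated value is 50000 nM, spanning 15000 nM to 100000 nM. The expected step is therefore a number no higher from compound 2 to compound 3 (the limit leaves the size open).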

Compound 3, half-maximal inhibitory concentration: > 50000 nM
Compound 3 gave a limit, no number; the forecaster's own chance of this, stated with the estimate: 65%; the middle value sits exactly at the limit.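

In this assay compound 3 gives > 50000 nM as a limit, not a number. Among these compounds, no step from compound 2 to compound 3 can therefore be read: the limit of > 50000 nM in this assay, at which 3 of the 3 values shown sit. The compounds shown leave open how strongly any of them acts and what formyl in place of hydroxymethyl does.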